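The compounds below may be only part of what the source reports. "The series", "measured", "known", "first", "only" and "open" are said of these compounds alone.

In an assay on cells for inhibition of Nicotinamide N-methyltransferase (Homo sapiens), with stated times of 10 min and 30 min (a higher number here means a weaker inhibitor, a lower number a stronger inhibitor), three close relatives of one adenosine-derived core have been examined. Compound 1 `CC(C)N(Cc1cccc(C(N)=O)c1)C[C@H]1O[C@@H](n2cnc3c(N)ncnc32)[C@H](O)[C@@H]1O` carries an isopropyl group and a carbamoyl group on its benzyl arm; in this assay compound 1 gives > 250000 nM, which is a limit of the assay. Compound 2 `NC(=O)CCCN(Cc1cccc(C(=O)O)c1)C[C@H]1O[C@@H](n2cnc3c(N)ncnc32)[C@H](O)[C@@H]1O` bears a carboxylic acid on the benzyl arm and a carbamoylpropyl chain on the amine nitrogen; in this assay compound 2 gives > 250000 nM, again a limit. Compound 3 `NC(=O)CCCCN(Cc1cccc(C(=O)O)c1)C[C@H]1O[C@@H](n2cnc3c(N)ncnc32)[C@H](O)[C@@H]1O` extends that chain by one carbon; in this assay compound 3 gives > 250000 nM, also a limit. The step that the two limits leave unreadable from compound 2 to compound 3 is therefore unreadable. Compound 3 thus stands only at a limit, as the evidence the limit of > 250000 nM in this assay, at which 3 of the 3 values shown sit, records for all three.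

Compound 4 `CC(C)N(Cc1cccc(C(=O)O)c1)C[C@H]1O[C@@H](n2cnc3c(N)ncnc32)[C@H](O)[C@@H]1O` differs from compound 3 by isopropyl in place of 4-carbamoylbutyl on an amine nitrogen. Compound 1 already carries the isopropyl group on the same amine nitrogen and sits at the limit, and the step from compound 2 to compound 3 gives no readable size. On this basis compound 4 is expected to remain at the limit as well, with an estimated value of 300000 nM and a range from 100000 nM to 1000000 nM. The expected step that the limit leaves unreadable from compound 3 to compound 4 is therefore estimated as none beyond the scatter.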

Compound 4, half-maximal inhibitory concentration: > 250000 nM
Compound 4: a limit, no number; the forecaster's own chance of this, stated with the estimate: 85%; the middle value is on the limit's open side.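

In this assay compound 4 gives > 250000 nM, which is a limit of the assay. Within the data shown here, no step from compound 1, compound 2 or compound 3 to compound 4 can be read. The compounds shown leave open how far any of these changes alters inhibition, because all of them rest at one limit: the limit of > 250000 nM in this assay, at which 4 of the 4 values shown sit.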